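A few compounds are considered here, and "the series" means these few. Any claim that something is new, unique, unknown or untested is made for them only; others in the source may bear on it.

Measured so far:
compound 1, `CC1C(=O)c2nc(CN3N=C(Cl)CCC3=O)[nH]c2N(C)C1=O`: > 100000 nM
compound 2, `CC1C(=O)c2nc(CCCN3N=C(Cl)CCC3=O)[nH]c2N(C)C1=O`: 8800 nM

Within the data shown here, in an assay on isolated protein for binding affinity to adenosine receptor A1 (Homo sapiens) (on this read-out lower numbers stand for stronger inhibition and higher numbers for weaker inhibition), compound 2 gives 8800 nM, the only plain number available here. Compound 1 is reported only as a limit of the assay, > 100000 nM, which is the limit of > 100000 nM in this assay, at which 1 of the 2 values shown sits. Compound 2 therefore stands as the single measured point from which a forecast can start.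

Compound 3, `CC1C(=O)c2nc(CCCN3N=C(c4ccccc4)CCC3=O)[nH]c2N(C)C1=O`, differs from compound 2 in one place: phenyl in place of chloro on a carbon with a double bond to nitrogen. Among the measured compounds shown here, no pair of measured compounds shows this exchange, so its effect has to be guessed rather than read off. A step beyond the scatter seems plausible in either direction; a modest gain is taken as the more likely outcome, with wide uncertainty. Compound 3 is therefore expected to show a 2.9-fold lower number from compound 2 to compound 3 (0.47 log units; beyond the scatter) in this assay. The estimated value of compound 3 is 3000 nM, within a range of 500 nM to 20000 nM.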

Compound 3, inhibition constant: 10800 nM
Compound 3: the middle estimate sits 3.6-fold (0.56 log units) below what was measured; measured number inside the range.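

In this assay the exchange gives a 1.2-fold higher number from compound 2 to compound 3 (0.09 log units; within the scatter) and so leaves the number where it was, even though phenyl brings a whole aromatic ring to a place that held only chloro. Compound 1 and compound 2 both carry chloro on this carbon with a double bond to nitrogen, so they could say nothing about this place, whereas this pair shows that it accepts the larger group with no change beyond the scatter. Nothing measured here bears on the reason for this result.

On these data alone, whether an amine, a methoxy group or a carboxylic acid at the same carbon would shift the number stays open. As far as these compounds go, it is also open whether a phenyl ring carrying a further group, such as fluoro or hydroxy, would behave as plain phenyl does.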